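From Bromo to Fluoro in a Series at the Limit

The compounds below may be only part of what the source reports. "The series", "measured", "known", "first", "only" and "open" are said of these compounds alone.

Three compounds sharing one core were tested in a functional assay on NCI-H460 cells (Homo sapiens) for antiproliferative activity, read by MTT assay, with a stated time of 48 h; a higher number here means a weaker inhibitor, a lower number a stronger inhibitor. Compound 1, `CC1(C)Cc2c(ccc(C(=O)/C=C/c3ccc(Cl)cc3Cl)c2OCc2ccccc2)O1`, gives only a limit in this assay, > 100000 nM. Compound 2, `CC1(C)Cc2c(ccc(C(=O)/C=C/c3ccccc3)c2OCc2ccccc2)O1`, likewise gives only a limit in this assay, > 100000 nM. Compound 3, `CC1(C)Cc2c(ccc(C(=O)/C=C/c3ccc(Br)cc3)c2OCc2ccccc2)O1`, also gives only a limit in this assay, > 100000 nM. Because every value sits at the limit of > 100000 nM in this assay, at which 3 of the 3 values shown sit, the steps among these compounds cannot be read: a step that the two limits leave unreadable from compound 1 to compound 2, a step that the two limits leave unreadable from compound 1 to compound 3 and a step that the two limits leave unreadable from compound 2 to compound 3 show only that none of the three entered the measurable range.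

Compound 4, `CC1(C)Cc2c(ccc(C(=O)/C=C/c3ccc(F)cc3)c2OCc2ccccc2)O1`, differs from compound 3 in one place: fluoro in place of bromo on an aromatic carbon. Among the measured compounds shown here, the one measured step touching that position, a step that the two limits leave unreadable from compound 2 to compound 3, was unreadable, so the numbers offer no direction for the change. Compound 3 rests at a limit, so compound 4 is most likely to return a limit as well, and the step is expected to be a step that the limit leaves unreadable from compound 3 to compound 4. Compound 4 is therefore estimated at 150000 nM, with a range from 40000 nM to 600000 nM.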

Compound 4, half-maximal inhibitory concentration: 75800 nM
The estimate for compound 4 lay 2.0-fold (0.30 log units) above the measured number; the range from low to high includes it.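

Compound 4 is the only compound shown that returns a number rather than a limit in this assay, so fluoro on this ring, para to a large group, is the one group here that brings the series into the measurable range: the limit of > 100000 nM in this assay, at which 3 of the 4 values shown sit. Set against the other compounds, the result gives only floors, namely an at least 1.3-fold lower number from compound 3 to compound 4 (0.12 log units; that floor lies within the scatter) and an at least 1.3-fold lower number from compound 2 to compound 4 (0.12 log units; that floor lies within the scatter) and an at least 1.3-fold lower number from compound 1 to compound 4 (0.12 log units; that floor lies within the scatter) and no exact sizes. Each floor lies within the scatter, so no real gain of fluoro over bromo, hydrogen or the 2,4-dichlorophenyl pattern is shown, and the steps among the three compounds at the limit still cannot be read.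

As far as these compounds go, whether a chloro, a methoxy or an amine at this same place would also give a number remains open. So does the true size of the change from bromo to fluoro.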